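Swapping the Amino Alcohol Tail for a Diamine Chain

The source may report more compounds than this note shows. Statements on the series, on what has been measured and on what is new or still open speak of the compounds shown alone.

For the measured compounds named here, compound 2 `CCCCCCCCCCc1ccc(-c2noc(CC(O)CN)n2)cc1` gives 59% in an assay on HeLa cells for inhibition of sphingosine-1-phosphate transporter SPNS2 (Mus musculus), read by LC-MS, tested at 2 uM (a lower number here means less inhibition, a higher number more inhibition at the concentration tested (going by the name of the read-out)), the highest of the two numbers known so far, while compound 1 `CCCCCCCCCCc1ccc(-c2noc(C3CCNC3)n2)cc1` gives 26% in the same assay. Going by the values given here, the single measured step, a number 33 percentage points higher from compound 1 to compound 2 (beyond the scatter), is the only comparison available. Compound 3 `CCCCCCCCCCc1ccc(-c2noc([C@@H](N)CCCCN)n2)cc1` differs from compound 2 by 1,5-diaminopentyl in place of 3-amino-2-hydroxypropyl on an aromatic carbon. Among the compounds with values here, no measured step matches this change, so any expectation rests on compound 2 alone at 59%. The step of a number 3 percentage points higher from compound 2 to compound 3 (within the scatter) is expected to stay within the scatter. Compound 3 is therefore estimated at 62%, in a range from 40% to 82%.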

Compound 3, a percentage reported as inhibition, at one concentration (the size of the read-out at that concentration, not a potency): 43%
Beside the measured number, compound 3's estimate is 19 percentage points above it; low and high end bracket the measured number.
By their numbers in this assay, from the lowest: compound 1; then compound 3; then compound 2.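

At this position, 1,5-diaminopentyl gives a number 16 percentage points lower from compound 2 to compound 3 (beyond the scatter) and a number 17 percentage points higher from compound 1 to compound 3 (beyond the scatter) in this assay and so ranks in the middle of the three groups. Both chains without a ring now score above the pyrrolidin-3-yl of compound 1, and a chain need not carry the hydroxyl of compound 2 to do so. Nothing measured here explains these differences. From the compounds shown here alone, whether the drop from compound 2 follows the lost hydroxyl, the second amine or the longer chain stays open, as does the role of the stereocentre in compound 3. A shorter diamine chain or a carboxylic acid at this position could help separate these features.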